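A free amine in place of the chloroaroyl amide

The source may report more compounds than this note shows. Statements on the series, on what has been measured and on what is new or still open speak of the compounds shown alone.

Compound 3 `COc1cc(/C=C/C(=O)c2cccc(NC(=O)c3ccc(Cl)cc3)c2)ccc1O` has the lowest number of the three compounds in a functional assay on SiHa cells (Homo sapiens) for inhibition; on this read-out lower numbers stand for stronger inhibition and higher numbers for weaker inhibition: compound 3 gives 2.3 ug/mL, compound 1 `COc1cc(/C=C/C(=O)c2cccc(NC(=O)c3cccs3)c2)ccc1O` gives 6.57 ug/mL, and compound 2 `COc1cc(/C=C/C(=O)c2cccc(NC(=O)c3cc(Cl)cc(Cl)c3)c2)ccc1O` gives 17.7 ug/mL. The steps among them, a 2.9-fold lower number from compound 1 to compound 3 (0.46 log units; beyond the scatter), a 2.7-fold higher number from compound 1 to compound 2 (0.43 log units; beyond the scatter) and a 7.7-fold lower number from compound 2 to compound 3 (0.89 log units; beyond the scatter), all arise from exchanging one group on the carbonyl carbon for another. Compound 4 `COc1cc(/C=C/C(=O)c2cccc(N)c2)ccc1O` goes further: hydrogen in place of (4-chlorophenyl)carbonyl on a nitrogen on an aromatic ring. Among the measured compounds shown here, none of the measured steps removes the carbonyl group altogether, so no step bears directly on this change; they show only that the group on the carbonyl carbon moves the number in this assay by modest amounts in either direction. The whole carbonyl-bearing group is absent in compound 4, and its number in this assay is therefore expected to rise, with the step of a 3.9-fold higher number from compound 3 to compound 4 (0.59 log units; beyond the scatter) estimated to lie beyond the scatter. Compound 4 is expected to give about 9 ug/mL, within a range from 3 ug/mL to 30 ug/mL.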

Compound 4, half-maximal inhibitory concentration: 12.3 ug/mL
For compound 4 the middle estimate is 1.4-fold (0.14 log units) below the measured one; the measured number falls inside the stated range.
By their numbers in this assay, from the lowest: compound 3; then compounds 1, 4 and 2 (each within the scatter of the next, the first and the last beyond it).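

In this assay, taking the whole (4-chlorophenyl)carbonyl off the nitrogen on the aromatic ring gives a 5.3-fold higher number from compound 3 to compound 4 (0.73 log units; beyond the scatter), so the free amine does not keep the low number seen with this group. The same exchange behaves differently for the other two groups: hydrogen in place of (3,5-dichlorophenyl)carbonyl gives a 1.4-fold lower number from compound 2 to compound 4 (0.16 log units; within the scatter), and hydrogen in place of (thiophen-2-yl)carbonyl gives a 1.9-fold higher number from compound 1 to compound 4 (0.27 log units; within the scatter), both within the scatter. Of the three carbonyl-bearing groups, then, only the (4-chlorophenyl)carbonyl separates from hydrogen beyond the scatter, so a carbonyl-bearing group on this nitrogen does not by itself lower the number.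

Nothing at hand explains why this exchange differs among the three groups. Going by these compounds, it remains open whether a simple acetyl on this nitrogen, or a methyl in place of one amine hydrogen, would stay near compound 4 or approach compound 3.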